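A few compounds are considered here, and "the series" means these few. Any claim that something is new, unique, unknown or untested is made for them only; others in the source may bear on it.

The three measured compounds share one core, each carrying an acyl group on the ring nitrogen and an amide to an aryl ring. Compound 1 `CC(=O)N1c2ccccc2CCC1C(=O)Nc1ccccc1O` pairs an acetyl group with a hydroxyphenyl amide. In a functional assay on MDA-MB-231 cells (Homo sapiens) for cytotoxicity, read by sulforhodamine B assay, with a stated time of 72 h (a higher number here means a weaker inhibitor of growth, a lower number a stronger inhibitor of growth), compound 1 gives 89600 nM. Compound 2 `CCCC(=O)N1c2ccccc2CCC1C(=O)Nc1ccccc1C(F)(F)F` carries a butanoyl group and a trifluoromethylphenyl amide. In this assay compound 2 reaches only the limit of the assay, > 70000 nM, so no number is available for it (the limit of > 70000 nM in this assay, at which 1 of the 3 values shown sits). Compound 3 `CCCCCCCCC(=O)N1c2ccccc2CCC1C(=O)Nc1cc(C(F)(F)F)cc(C(F)(F)F)c1` combines a nonanoyl group with a bis(trifluoromethyl)phenyl amide, and in this assay compound 3 gives 7530 nM. Among the compounds with values here, of the two numbers known, compound 1 has the higher one, and its gap to compound 3 lies beyond the scatter; since the two differ in both the acyl chain and the aryl ring, the two changes cannot be told apart.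

Compound 4 `CCCCCCCCC(=O)N1c2ccccc2CCC1C(=O)Nc1ccccc1O` keeps the hydroxyphenyl amide of compound 1 and alters only the acyl group: heptyl in place of hydrogen on a saturated chain carbon bound to a carbonyl carbon. Within the data shown here, no measured pair isolates this change. Compound 3, at 7530 nM, carries the same nonanoyl group and sits well below compound 1, which hints at a downward direction. A downward step beyond the scatter is therefore expected, a 3.6-fold lower number from compound 1 to compound 4 (0.55 log units; beyond the scatter). In this assay compound 4 is estimated at 25000 nM, with a range from 8000 nM to 80000 nM.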

Compound 4, concentration for 50% growth inhibition: 54300 nM
The estimate for compound 4 lay 2.2-fold (0.34 log units) below the measured number; measured number inside the range.
By their numbers in this assay, from the lowest: compound 3; then compounds 4 and 1 (each within the scatter of the next).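

Within the data shown here, this is the first pair in which the acyl group changes alone while the hydroxyphenyl amide stays in place, so the acyl change can now be read apart from any change in the aryl ring. In this assay, heptyl in place of hydrogen on a saturated chain carbon bound to a carbonyl carbon, which is the same difference as acetyl to octylcarbonyl, gives a 1.7-fold lower number from compound 1 to compound 4 (0.22 log units; within the scatter). With this amide, then, the added chain brings no difference that can be told from the scatter, and nothing measured on the compounds bears on this step or offers a cause for it.

As far as these compounds go, what remains open is whether a longer chain on the acyl group, or an amine carried on that chain, would move the number away from the scatter with the hydroxyphenyl amide in place. It is also open how the same change from acetyl to octylcarbonyl would read on an amide carrying a trifluoromethyl or a carboxylic acid group, as no pair shown makes this change on any aryl ring other than the hydroxyphenyl one.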